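The source may report more compounds than this note shows. Statements on the series, on what has been measured and on what is new or still open speak of the compounds shown alone.

Working notes on the series. In an assay on HeLa cells for displacement of a labelled ligand from adenosine receptor A3 (Homo sapiens), with a stated time of 180 min, tested at 1 uM (a lower number here means less inhibition, a higher number more inhibition at the concentration tested (going by the name of the read-out)), compound 1 `CCOC(=O)C1=C(C)NC(=O)NC1C1CCCC1` gives 18%, compound 2 `CC1=C(C(=O)OC(C)C)[C@@H](c2ccco2)N/C(=N/C#N)N1` gives 4% and compound 3 `CCOC(=O)C1=C(C)N/C(=N\C#N)NC1c1cccs1` gives 3%. Compound 3 has the lowest of the three numbers: its value and that of compound 2 lie within the scatter of each other, whereas compound 1 sits beyond the scatter above it. Compound 4 `CCOC(=O)C1=C(C)N/C(=N\C#N)NC1C1CCCC1` has not yet been measured in this assay. It differs from compound 3 by cyclopentyl in place of thiophen-2-yl on a saturated ring carbon. Among the compounds with values here, no step between measured compounds isolates this change, since compound 1 and compound 3 differ in more than one place. The step from compound 3 to compound 4 in this assay is expected to be small, a number 6 percentage points higher from compound 3 to compound 4 (within the scatter), with no change beyond the scatter. For compound 4 the estimate is 9%, ranging from 0% to 22%.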

Compound 4, a percentage reported as inhibition, at one concentration (the size of the read-out at that concentration, not a potency): 4%
Compound 4: middle estimate off by 5 percentage points, on the high side; measured number inside the range.
By their numbers in this assay, from the lowest: compounds 3, 2 and 4 (each within the scatter of the next); then compound 1.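

Cyclopentyl in place of thiophen-2-yl on the saturated ring carbon gives a number 1 percentage points higher from compound 3 to compound 4 (within the scatter) in this assay, the first step in the series to isolate this position. On this core, the read-out therefore does not separate the five-membered aromatic ring from the non-aromatic carbon ring. No supporting measurement bears on why the two groups are not separated.

Still open, on these data alone, is whether a phenyl group or a longer alkyl chain on this ring carbon would give a step beyond the scatter.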